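A Trifluoromethoxy Variant of Compound 1

The source may hold more compounds than are shown below. What is called first, only, known or untested is meant among the compounds shown, and "the series" means these compounds.

Compound 1 `CC(C#Cc1cccc(C(=O)NCCC(c2ccccc2)c2ccccc2)c1)N(O)C(N)=O`: 300 nM
Compound 2 `CC(C#Cc1cccc(C(=O)NCc2cccc(F)c2)c1)N(O)C(N)=O`: 4000 nM
Compound 3 `C[C@H](C#Cc1cccc(C(=O)NCCC(c2ccccc2)c2ccc(S(N)(=O)=O)cc2)c1)N(O)C(N)=O`: 1000 nM

All three were tested in an assay for inhibition of Polyunsaturated fatty acid 5-lipoxygenase (Homo sapiens), read by HPLC, with stated times of 15 min and 10 min; on this read-out higher numbers stand for weaker inhibition and lower numbers for stronger inhibition. Compound 1 gives the lowest number of the three; compound 3 comes nearest with a higher number, and compound 2 lies furthest with a number higher still, both gaps beyond the scatter. Compound 4 `CC(C#Cc1cccc(C(=O)NCCC(c2ccccc2)c2ccc(OC(F)(F)F)cc2)c1)N(O)C(N)=O` is not yet measured. It differs from compound 1 by a single change: trifluoromethoxy in place of hydrogen on an aromatic carbon. Among the compounds with values here, no measured pair isolates this change, so its effect can only be expected, not read. Compound 4 is therefore expected to sit close to compound 1, with a step of a 1.5-fold higher number from compound 1 to compound 4 (0.18 log units; within the scatter) that stays within the scatter. The estimate for compound 4 in this assay is 450 nM, between 150 nM and 1400 nM.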

Compound 4, half-maximal inhibitory concentration: 110 nM
The estimate for compound 4 lay 4.1-fold (0.61 log units) above the measured number; measured number outside the range, below it.
By their numbers in this assay, from the lowest: compound 4; then compound 1; then compound 3; then compound 2.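

In this assay, within the data shown here, trifluoromethoxy in place of hydrogen on an aromatic carbon gives a 2.7-fold lower number from compound 1 to compound 4 (0.44 log units; beyond the scatter) as the first step that isolates a single change. It shows that this position, para to a large group, tolerates the added group, and that here the number falls rather than rises. Nothing measured here explains the gain.

On these data alone, whether a trifluoromethyl, a methoxy or a single fluorine at this place would do the same remains open. So does whether trifluoromethoxy on the second phenyl would lower the number further.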